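A methoxypyridine in place of the ethoxypyrimidine

This account rests on a few compounds, and the source may have more. Where it says the series, first, only, none or still open, it means among the compounds named here.

Compound 2 `CCOc1ncc(-c2nc(C(F)(F)F)sc2N2CCN(C(=O)Cn3nc(C)nc3C)[C@H](C)C2)cn1` stands highest of the three numbers in a functional assay on U2OS cells for antagonist activity at C-X-C chemokine receptor type 3 (Homo sapiens), read by beta-arrestin recruitment (on this read-out higher numbers stand for weaker inhibition and lower numbers for stronger inhibition), at 173 nM. Compound 3 `CCOc1ncc(-c2nc(C(F)(F)F)sc2N2CCN(C(=O)Cn3cnc(C(F)(F)F)n3)[C@H](C)C2)cn1` gives 118 nM, and the step between them lies within the scatter: a 1.5-fold lower number from compound 2 to compound 3 (0.17 log units; within the scatter). Compound 1 `CCOc1ncc(-c2nc(C(F)(F)F)sc2N2CCN(C(=O)Cn3ccc4cccnc43)[C@H](C)C2)cn1` gives 47 nM; the step of a 3.7-fold higher number from compound 1 to compound 2 (0.57 log units; beyond the scatter) is beyond the scatter, as is a 2.5-fold higher number from compound 1 to compound 3 (0.40 log units; beyond the scatter).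

Compound 4 `COc1ccc(-c2nc(C(F)(F)F)sc2N2CCN(C(=O)Cn3nc(C)nc3C)[C@H](C)C2)cn1` differs from compound 2 at a different part of the molecule: 6-methoxypyridin-3-yl in place of 2-ethoxypyrimidin-5-yl on an aromatic carbon. Within the data shown here, none of the measured steps touches this position; all three vary the group on the saturated chain carbon bound to a carbonyl carbon. Among the measured compounds shown here, no measured step therefore bears on this change, and no step beyond the scatter is expected in this assay in either direction. Compound 4 is estimated at 200 nM, between 80 nM and 500 nM, an expected step of a 1.2-fold higher number from compound 2 to compound 4 (0.06 log units; within the scatter).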

Compound 4, half-maximal inhibitory concentration: 1170 nM
Beside the measured number, compound 4's estimate is 5.9-fold (0.77 log units) below it; the whole stated range lies below it.
By their numbers in this assay, from the lowest: compound 1; then compounds 3 and 2 (each within the scatter of the next); then compound 4.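

In this assay, among these compounds, the group on this aromatic carbon proves to matter: 6-methoxypyridin-3-yl in place of 2-ethoxypyrimidin-5-yl gives a 6.8-fold higher number from compound 2 to compound 4 (0.83 log units; beyond the scatter), which the earlier compounds, all varied on the saturated chain carbon, could not show. The change alters the ring and the alkoxy chain at once, so the step cannot be assigned to either alone. Nothing available explains the step. The compounds shown leave open how 2-methoxypyrimidin-5-yl or 6-ethoxypyridin-3-yl would read here, and either would separate the two changes.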